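The compounds below may be only part of what the source reports. "The series", "measured", "known", "first", "only" and "open" are said of these compounds alone.

Measured in a functional assay on HCT-116 cells (Homo sapiens) for antiproliferative activity, read by MTT assay, with a stated time of 48 h; a higher number here means a weaker inhibitor, a lower number a stronger inhibitor:
Compound 1 `CCc1ccccc1-n1nncc1CN1C(=O)C2(C(C#N)=C(N)Oc3c(N)cc4nc5ccccc5nc4c32)c2ccccc21`: 10300 nM
Compound 2 `COc1ccccc1-n1nncc1CN1C(=O)C2(C(C#N)=C(N)Oc3c(N)cc4nc5ccccc5nc4c32)c2ccccc21`: > 50000 nM
Compound 3 `Cc1ccc(-n2nncc2CN2C(=O)C3(C(C#N)=C(N)Oc4c(N)cc5nc6ccccc6nc5c43)c3ccccc32)cc1C`: > 50000 nM

The value of compound 3 is a limit of this assay, not a measured number. Compound 2 also reached only that limit (the limit of > 50000 nM in this assay, at which 2 of the 3 values shown sit). Among the measured compounds shown here, compound 1 is therefore the one compound with a real number, and compound 3 stands at the weak end of what was seen. Two readable steps lead away from compound 1: an at least 4.8-fold higher number from compound 1 to compound 3 (0.68 log units; beyond the scatter), and an at least 4.8-fold higher number from compound 1 to compound 2 (0.68 log units; beyond the scatter). Between the two limit compounds the step is a step that the two limits leave unreadable from compound 2 to compound 3.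

Compound 4 `N#CC1=C(N)Oc2c(N)cc3nc4ccccc4nc3c2C12C(=O)N(Cc1cnnn1-c1c(F)cccc1F)c1ccccc12` differs from compound 3 in one place: 2,6-difluorophenyl in place of 3,4-dimethylphenyl on an aromatic nitrogen. For the measured compounds named here, both steps that bear on the aromatic nitrogen start from compound 1 and end at a limit, so they show only that two other aryl groups were weaker than 2-ethylphenyl; no step measures a difluorophenyl, and the starting point, compound 3, is itself a limit. The direction of the step from compound 3 is thus not fixed by the data. Compound 4 is expected to be a weak inhibitor, estimated near 30000 nM, with a range from 8000 nM to 100000 nM. The expected step is an at least 1.6-fold lower number from compound 3 to compound 4 (0.22 log units; that floor lies within the scatter).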

Compound 4, half-maximal inhibitory concentration: > 50000 nM
Compound 4 was reported as a limit (the forecaster's own chance of this, stated with the estimate: 50%); at least 1.6-fold (0.22 log units) between middle value and limit.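

In this assay compound 4 gives > 50000 nM as a limit of the assay, not a number. With 2,6-difluorophenyl on the aromatic nitrogen there is an at least 4.8-fold higher number from compound 1 to compound 4 (0.68 log units; beyond the scatter) and so a third aryl group, one carrying fluorine rather than carbon or oxygen substituents, falls short of the 2-ethylphenyl of compound 1. The steps among compound 2, compound 3 and compound 4 cannot be read, and most of the series now rests on a single limit: the limit of > 50000 nM in this assay, at which 3 of the 4 values shown sit.

Going by these compounds, only the 2-ethylphenyl group gives a real number, so it remains open whether a 2-methylphenyl or 2-propylphenyl group would also give one. On these data alone, how a plain phenyl or a 2-aminophenyl group would read at this position is also open.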